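This account rests on a few compounds, and the source may have more. Where it says the series, first, only, none or still open, it means among the compounds named here.

In an ADME assay on HS27 cells (Homo sapiens) for cytotoxicity, read by MTT assay, with a stated time of 24 h (a lower number here means a stronger inhibitor of growth, a higher number a weaker inhibitor of growth), two compounds sharing part of their structure have been measured. Compound 1 `Cc1ccc(NC(=O)Cc2c[nH]c3ccccc23)cc1NC(=O)c1cnoc1C` gives > 30000 nM, which is a limit of the assay and not a number. Compound 2 `Cc1ccc(NC(=O)Nc2ccccc2F)cc1NC(=O)c1cnoc1C` gives > 30000 nM, which is also a limit and not a number. Neither compound therefore has a measured number, and both stand at the limit of > 30000 nM in this assay, at which 2 of the 2 values shown sit.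

Compound 3 `Cc1ccc(NC(=O)Nc2cccc(Cl)c2)cc1NC(=O)c1cnoc1C` has yet to be measured in this assay. It departs from compound 2 in one place, with 3-chlorophenyl in place of 2-fluorophenyl on an amide-type nitrogen. Within the data shown here, no step between measured compounds is available to show what a change of this kind does. The expectation therefore rests on compound 2 with its limit of > 30000 nM, and on the matching limit of compound 1. No shift beyond the usual scatter is expected, in either direction, and the estimated change is a number no higher from compound 2 to compound 3 (the limit leaves the size open). A further report of a limit rather than a number is also expected. The estimate for compound 3 is 30000 nM, with an expected range of 12000 nM to 60000 nM.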

Compound 3, concentration for 50% growth inhibition: > 30000 nM
Compound 3: no number, only a limit; the forecaster's own chance of this, stated with the estimate: 80%; the middle value sits exactly at the limit.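

In this assay compound 3 gives > 30000 nM, which is a limit and not a number. Compound 2 likewise gives only a limit, > 30000 nM, so no step can be read between compound 2 and compound 3. The compounds shown leave open whether any change of group on the shared core would yield a measured number, as all stand at one value: the limit of > 30000 nM in this assay, at which 3 of the 3 values shown sit.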